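Removing a Carboxy Group from the Aryl Amine Substituent

A few compounds are considered here, and "the series" means these few. Any claim that something is new, unique, unknown or untested is made for them only; others in the source may bear on it.

Within the data shown here, compound 2 `CC1=NN(C(=O)c2cc3ccccc3oc2=O)C(=O)C1CNc1ccc(O)c(C(=O)O)c1` stands lowest of the two compounds measured so far in a functional assay on the whole organism for inhibition, with Rattus norvegicus as the target, read by paw edema, with stated times of 1 h and 6 h, at a dose of 0.03 mg/kg by the oral route (a higher number here means more inhibition at the dose given (going by the name of the read-out), a lower number less inhibition), giving 50.9%. Compound 1 `CC1=NN(C(=O)c2cc3ccccc3oc2=O)C(=O)C1CNc1cccc(S(N)(=O)=O)c1` gives 79.9%, and the step of a number 29 percentage points lower from compound 1 to compound 2 (beyond the scatter) shows how much the group on the amine nitrogen can matter. Compound 3 `CC1=NN(C(=O)c2cc3ccccc3oc2=O)C(=O)C1CNc1ccc(O)cc1` differs from compound 2 by hydrogen in place of carboxy on an aromatic carbon. Among the measured compounds shown here, no measured step removes a carboxy group alone, so the one step between compound 1 and compound 2 bears only loosely on this change. The expected step of a number 4.1 percentage points higher from compound 2 to compound 3 (within the scatter) is small, with no clear direction. Compound 3 is estimated at 55%, within 30% to 80%.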

Compound 3, a percentage reported as inhibition, in the whole organism at one dose (the size of the read-out at that dose, not a potency): 50.7%
The estimate for compound 3 lay 4.3 percentage points above the measured number; the range from low to high includes it.
By their numbers in this assay, from the lowest: compounds 3 and 2 (each within the scatter of the next); then compound 1.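

In this assay, hydrogen in place of carboxy gives a number 0.2 percentage points lower from compound 2 to compound 3 (within the scatter), so at this position the two cannot be told apart at this dose. With the carboxy group gone, 4-hydroxyphenyl in place of 3-sulfamoylphenyl still gives a number 29.2 percentage points lower from compound 1 to compound 3 (beyond the scatter), so the loss of the carboxy group does not close the gap to compound 1. Nothing measured here explains that gap.

On these data alone, whether an amine or a methoxy group in place of the hydroxy group would shift the number stays open. Also open, as far as these compounds go, is whether the sulfamoyl group itself, or its place on the ring, sets compound 1 apart.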